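The source may hold more compounds than are shown below. What is called first, only, known or untested is meant among the compounds shown, and "the series" means these compounds.

Three compounds have been measured in a functional assay on DU-145 cells (Homo sapiens) for inhibition, read by trypan blue exclusion, with a stated time of 96 h (on this read-out higher numbers stand for weaker inhibition of growth and lower numbers for stronger inhibition of growth), and give these values:

compound 1 (`O=C(/C(=C\c1ccccc1OCc1ccccc1)SCc1ccc(F)cc1)c1ccc(Cl)cc1`) gives 1000 nM
compound 2 (`O=C(/C(=C\c1ccccc1OCc1ccccc1)S(=O)(=O)Cc1ccc(F)cc1)c1ccc(Cl)cc1`) gives 10000 nM
compound 3 (`COc1ccc(S/C(=C/c2ccccc2OCc2ccccc2)C(=O)c2ccc(Cl)cc2)cc1`) gives 1000 nM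

Compound 3 stands level with compound 1 in this assay, and the remaining comparison is a 10-fold lower number from compound 2 to compound 3 (1.00 log units; beyond the scatter), so these two share the low end of the three numbers.

The unmeasured compound 4 (`O=C(/C(=C\c1ccccc1OCc1ccccc1)S(=O)(=O)c1ccc(Br)cc1)c1ccc(Cl)cc1`) differs from compound 3 by (4-bromophenyl)sulfonyl in place of (4-methoxyphenyl)sulfanyl on a double-bonded chain carbon bound to a carbonyl carbon and a double-bonded chain carbon. The closest measured precedent for the sulfonyl part is a 10-fold higher number from compound 1 to compound 2 (1.00 log units; beyond the scatter), where (4-fluorobenzyl)sulfonyl replaces (4-fluorobenzyl)sulfanyl. The group on the sulfur has one measured comparison, no change at the digits printed from compound 1 to compound 3 (within the scatter), with 4-methoxyphenyl in place of 4-fluorobenzyl. Among the measured compounds shown here, no measured compound carries 4-bromophenyl, so that part of the change remains open. A rise in the number, somewhat short of the sulfonyl precedent or equal to it, is therefore what the data suggest. The expected step is a 6.0-fold higher number from compound 3 to compound 4 (0.78 log units; beyond the scatter) in this read-out. For compound 4 the estimated value is 6000 nM, with an expected range from 1500 nM to 20000 nM.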

Compound 4, concentration for 50% growth inhibition: 1000 nM
Compound 4: the middle estimate sits 6.0-fold (0.78 log units) above what was measured; measured number outside the range, below it.
By their numbers in this assay, from the lowest: compounds 1, 3 and 4 (each within the scatter of the next); then compound 2.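

In this assay a sulfonyl on a double-bonded chain carbon bound to a carbonyl carbon and a double-bonded chain carbon does not by itself go with a higher number: 4-bromophenyl on that sulfur gives no change at the digits printed from compound 3 to compound 4 (within the scatter) and also no change at the digits printed from compound 1 to compound 4 (within the scatter) against the sulfanyl compounds. The group on the sulfur was silent in the sulfanyl pair, with no change at the digits printed from compound 1 to compound 3 (within the scatter) for 4-methoxyphenyl in place of 4-fluorobenzyl, but it counts on the sulfonyl, where 4-bromophenyl in place of 4-fluorobenzyl gives a 10-fold lower number from compound 2 to compound 4 (1.00 log units; beyond the scatter) and the high number of compound 2 is thereby tied to sulfonyl and 4-fluorobenzyl together, not to sulfonyl alone. Nothing at hand explains why these two groups part on the sulfonyl sulfur.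

Compound 2 and compound 4 differ at once in the bromine against the fluorine and in the methylene link to the ring, so the compounds shown do not say which of these carries the step, and a 4-bromobenzyl group on the sulfonyl sulfur would separate them. As far as these compounds go, how a sulfonyl behaves with 4-methoxyphenyl, or with an amine or a carboxylic acid on that ring, also remains open.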